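This account rests on a few compounds, and the source may have more. Where it says the series, first, only, none or still open, it means among the compounds named here.

Measured compounds in a functional assay on CHO cells for inhibition of transient receptor potential cation channel subfamily V member 1 (Homo sapiens); a lower number here means a stronger inhibitor, a higher number a weaker inhibitor:

compound 1 `CC(C)(C)c1ccc(/C=C/C(=O)Nc2ccc3c(c2)NC(=O)CO3)cc1`, giving 6.5 nM 
compound 2 `CCCCc1ccc(/C=C/C(=O)Nc2ccc3c(c2)OCCO3)cc1`, giving 360 nM 

Compound 2 stands highest of the two numbers; its nearest neighbour, compound 1, gives a far lower number, and the gap lies beyond the scatter. Going by the values given here, compound 1 and compound 2 differ in more than one place, so no single-point step is available between them, and nothing about the change below can be read from that pair.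

Compound 3 `O=C(/C=C/c1ccc(F)cc1)Nc1ccc2c(c1)OCCO2` is not yet measured. It differs from compound 2 by fluoro in place of butyl on an aromatic carbon. A chain of four carbons is replaced by a single fluorine at the same aromatic carbon.

Among the compounds with values here, with no comparable step among the measured compounds, the expectation for this assay rests on the change alone: the step from compound 2 to compound 3 is expected to run upward, toward a weaker inhibitor, by about a 4.2-fold higher number from compound 2 to compound 3 (0.62 log units; beyond the scatter). Compound 3 is accordingly estimated at 1500 nM, with a range of 300 nM to 8000 nM.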

Compound 3, half-maximal inhibitory concentration: 1000 nM
Estimate against measurement, compound 3: 1.5-fold (0.18 log units) above; the measured number falls inside the stated range.
By their numbers in this assay, from the lowest: compound 1; then compound 2; then compound 3.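

In this assay, going by these compounds alone, the first single-place step, on an aromatic carbon para to a large group, gives a 2.8-fold higher number from compound 2 to compound 3 (0.44 log units; beyond the scatter) and so places butyl ahead of fluoro at this position, on this one pair only. Going from a chain of four carbons to a single fluorine weakens inhibition only modestly, so a four-carbon chain is not essential here for the activity these two compounds show. Nothing measured here accounts for the direction or the size of this step.

Going by these compounds, whether a trifluoromethyl, a methoxy or a longer chain at the same carbon would lower the number remains open. On these data alone, the separate contributions of the tert-butyl group and the core of compound 1 also remain open, as compound 1 differs from compound 2 and compound 3 in more than one place.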